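The source may hold more compounds than are shown below. What is called first, only, known or untested is meant among the compounds shown, and "the series" means these compounds.

Measured compounds:
compound 1 `Nc1cc(N)c2nc(-c3ccccc3)c(Oc3ccc(Cl)c(Cl)c3)nc2c1`: 33900 nM
compound 2 `COc1ccc(CNc2nc3cc(N)cc(N)c3nc2-c2ccccc2)cc1OC`: 3310 nM
compound 3 `Nc1cc(N)c2nc(-c3ccccc3)c(NCc3ccc(F)cc3)nc2c1`: 4070 nM

All three were tested in a functional assay on SR cells (Homo sapiens) for inhibition, read by sulforhodamine B assay, with a stated time of 48 h; on this read-out lower numbers stand for stronger inhibition of growth and higher numbers for weaker inhibition of growth. Compound 3 stands second highest of the three numbers, close to compound 2 and far from compound 1. The step of a 1.2-fold higher number from compound 2 to compound 3 (0.09 log units; within the scatter) lies within the scatter, so compound 2 and compound 3 cannot be told apart. The step of an 8.3-fold lower number from compound 1 to compound 3 (0.92 log units; beyond the scatter) is the only one beyond the scatter: replacing a phenoxy-type group with a benzylamino-type group on the shared core lowered the number by a modest amount.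

Compound 4 `Nc1cc(N)c2nc(-c3ccccc3)c(Oc3ccc(F)cc3)nc2c1` has not yet been measured. It differs from compound 3 in one place: 4-fluorophenoxy in place of (4-fluorobenzyl)amino on an aromatic carbon. This change partly reverses the move seen in an 8.3-fold lower number from compound 1 to compound 3 (0.92 log units; beyond the scatter), returning from a nitrogen-linked group to an oxygen-linked group, although the halogen pattern on the ring also differs. The step of a 1.2-fold higher number from compound 2 to compound 3 (0.09 log units; within the scatter) suggests such ring substituent changes matter little here. A higher number is therefore expected for compound 4, estimated as a 3.7-fold higher number from compound 3 to compound 4 (0.57 log units; beyond the scatter), though smaller than the full earlier step. The estimate for compound 4 is 15000 nM, with a range from 5000 nM to 45000 nM.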

Compound 4, concentration for 50% growth inhibition: 8130 nM
Compound 4: middle estimate off by 1.8-fold (0.27 log units), on the high side; low and high end bracket the measured number.
By their numbers in this assay, from the lowest: compounds 2, 3 and 4 (each within the scatter of the next, the first and the last beyond it); then compound 1.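

In this assay, exchanging (4-fluorobenzyl)amino for 4-fluorophenoxy on this aromatic carbon, next to the ring nitrogen, gives a 2.0-fold higher number from compound 3 to compound 4 (0.30 log units; within the scatter), so with a 4-fluoro ring on both sides this change of linked group cannot be told from scatter. The ring on the oxygen, however, does register: 4-fluorophenyl in place of 3,4-dichlorophenyl gives a 4.2-fold lower number from compound 1 to compound 4 (0.62 log units; beyond the scatter), so the earlier step from compound 1 to compound 3 cannot be read as a matter of the oxygen or nitrogen link alone. Nothing measured here accounts for these results.

Which feature of the 3,4-dichlorophenyl ring matters remains open, and a 4-chlorophenoxy group would separate the two chlorine positions. Going by these compounds, it is also open how this position would respond to a morpholine ring or a longer chain such as 2-phenylethylamino.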